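Swapping Two Chlorines for One Fluorine on the Phenoxy Arm

The source may hold more compounds than are shown below. What is called first, only, known or untested is meant among the compounds shown, and "the series" means these compounds.

Measured so far in a functional assay on K562 cells (Homo sapiens) for inhibition, read by sulforhodamine B assay, with a stated time of 48 h; a lower number here means a stronger inhibitor of growth, a higher number a weaker inhibitor of growth:
Compound 1 `Nc1cc(N)c2nc(-c3ccccc3)c(Oc3ccc(Cl)c(Cl)c3)nc2c1` gives 3550 nM.
Compound 2 `CCOC(=O)[C@H](CCC(=O)O)NC(=O)c1ccc(Sc2nc3cc(N)cc(N)c3nc2-c2ccccc2)cc1` reaches only (the limit of > 10 nM in this assay, at which 1 of the 2 values shown sits); its entry, > 10 nM, is a limit rather than a number.

Compound 1 thus holds the only real number shown in this assay. Compound 3 `Nc1cc(N)c2nc(-c3ccccc3)c(Oc3ccc(F)cc3)nc2c1` differs from compound 1 in one place: 4-fluorophenyl in place of 3,4-dichlorophenyl on an oxygen on an aromatic ring. For the measured compounds named here, no measured step of this kind is available, so the size of the effect is unknown. The step of a 1.4-fold higher number from compound 1 to compound 3 (0.15 log units; within the scatter) is expected to be small, within the scatter or slightly toward weaker inhibition. Compound 3 is therefore estimated at 5000 nM, in the range 2000 nM to 12000 nM.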

Compound 3, concentration for 50% growth inhibition: 11000 nM
For compound 3 the middle estimate is 2.2-fold (0.34 log units) below the measured one; the measured number falls inside the stated range.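

Replacing 3,4-dichlorophenyl with 4-fluorophenyl on the oxygen gives a 3.1-fold higher number from compound 1 to compound 3 (0.49 log units; beyond the scatter) in this assay. For the compounds shown here, this modest step is the first measured sign that the group at this position affects growth inhibition, and the dichlorinated compound is the stronger of the pair. Going by these compounds alone, nothing measured so far explains the difference.

Within the data shown here, the single step removes two chlorines and adds one fluorine, so it cannot show which part of the swap matters. A 4-chlorophenyl group on the same oxygen would separate the two changes.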